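Amino in place of nitro on compound 2

A few compounds are considered here, and "the series" means these few. Any claim that something is new, unique, unknown or untested is made for them only; others in the source may bear on it.

Of the compounds shown here, two have been tested so far in a functional assay on T47D cells (Homo sapiens) for antiproliferative activity, read by MTT assay, with a stated time of 72 h (on this read-out higher numbers stand for weaker inhibition and lower numbers for stronger inhibition), and only one of them gives a number. For compound 1 `COc1cc(-c2nccn2S(=O)(=O)c2ccc(C)cc2)cc(OC)c1OC` the reading > 100000 nM is a limit of the assay and not a number. Within the data shown here, compound 2 `COc1ccc(NC(=O)c2cc(OC)c(OC)c(OC)c2)cc1[N+](=O)[O-]` gives 34500 nM as the only true number, so there is no second number against which to rank it. The next compound differs from it in one place. Compound 3 `COc1ccc(NC(=O)c2cc(OC)c(OC)c(OC)c2)cc1N` carries amino in place of nitro on an aromatic carbon, ortho to a methoxy group and meta to a large group (amino in place of nitro on an aromatic carbon). Among the measured compounds shown here, no measured pair shows what this exchange does in this assay so any forecast of its size remains uncertain. A moderate gain in inhibition is expected, though a result within the scatter or a shift the other way would not be surprising. The estimated change a 2.3-fold lower number from compound 2 to compound 3 (0.36 log units; beyond the scatter) is therefore only a modest one. For compound 3 the expected value is 15000 nM with an estimated range from 2500 nM to 70000 nM in this measurement.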

Compound 3, half-maximal inhibitory concentration: 50400 nM
The estimate for compound 3 lay 3.4-fold (0.53 log units) below the measured number; measured number inside the range.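

Amino in place of nitro on an aromatic carbon, ortho to a methoxy group and meta to a large group, gives a 1.5-fold higher number from compound 2 to compound 3 (0.16 log units; within the scatter) in this assay. Among these compounds, this is the first measured exchange at this position, and it shows that on this core, swapping a group with 3 heavy atoms, 0 hydrogen-bond donors and 2 hydrogen-bond acceptors for one with 1 heavy atom, 1 hydrogen-bond donor and 1 hydrogen-bond acceptor does not separate the two compounds on this read-out. Nothing among the measurements shown offers a reason for this outcome.

Going by these compounds, whether any other group on this aromatic carbon, such as a hydroxyl, an acetamide or a fluorine, would move the number beyond the scatter stays open, since one exchange cannot show how far this position tolerates change. Compound 1 stands at > 100000 nM, which is a limit of the assay and not a number, and it differs from the others in more than one place, so it adds nothing on this position.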